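The compounds below may be only part of what the source reports. "The series", "measured", "known", "first", "only" and "open" are said of these compounds alone.

In a functional assay on MCF7 cells (Homo sapiens) for inhibition, read by MTT assay, with a stated time of 72 h (a higher number here means a weaker inhibitor, a lower number a stronger inhibitor), compound 3 (`COc1cc(NC(C)CCCNC(=O)NNC(=O)Nc2cccc(F)c2)c2ncccc2c1`) gives 150 nM. Compound 2 (`COc1cc(NC(C)CCCNC(=O)NNC(=O)Nc2ccc(Br)cc2)c2ncccc2c1`) gives 100 nM, and the gap, a 1.5-fold higher number from compound 2 to compound 3 (0.18 log units; within the scatter), lies within the scatter. Compound 1 (`COc1cc(NC(C)CCCNC(=O)Nc2cccc(F)c2)c2ncccc2c1`) stands well apart at 18000 nM.

Compound 4 (`COc1cc(NC(C)CCCNC(=O)Nc2ccc(C(F)(F)F)cc2)c2ncccc2c1`) differs from compound 3 by having 4-(trifluoromethyl)phenyl in place of ((3-fluorophenyl)carbamoyl)amino on an amide-type nitrogen. The most relevant measured steps run the opposite way. Both a 120-fold lower number from compound 1 to compound 3 (2.08 log units; beyond the scatter) and a 180-fold lower number from compound 1 to compound 2 (2.26 log units; beyond the scatter) are large, and each puts a carbamoylamino-linked aryl group where compound 1 has a plain 3-fluorophenyl. Compound 4 loses that link, so in this respect it resembles compound 1.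

The aryl group itself has less support. Within the data shown here, the only measured swap, between 3-fluorophenyl and 4-bromophenyl, stays within the scatter, and no measured compound carries 4-(trifluoromethyl)phenyl. This makes the expectation uncertain, as it rests on just three compounds. A large rise in the number is still expected in this assay. The expected change is an 80-fold higher number from compound 3 to compound 4 (1.90 log units; beyond the scatter). Compound 4 is estimated at 12000 nM. The expected range for compound 4 runs from 3000 nM to 45000 nM.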

Compound 4, half-maximal inhibitory concentration: 1900 nM
Compound 4: middle estimate off by 6.3-fold (0.80 log units), on the high side, and the stated range ends above it.
By their numbers in this assay, from the lowest: compounds 2 and 3 (each within the scatter of the next); then compound 4; then compound 1.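

Without the carbamoylamino link, 4-(trifluoromethyl)phenyl on the amide-type nitrogen in this assay gives a 13-fold higher number from compound 3 to compound 4 (1.10 log units; beyond the scatter) and a 19-fold higher number from compound 2 to compound 4 (1.28 log units; beyond the scatter), so the large gap that earlier separated the linked compounds from a single directly attached 3-fluorophenyl compound also holds for a second directly attached aryl group. Among these compounds, what the earlier compounds could not show is that the aryl group can matter at this position: a 9.5-fold lower number from compound 1 to compound 4 (0.98 log units; beyond the scatter) is a step beyond the scatter between two directly attached aryl groups, whereas the only earlier aryl swap, within the linked pair, stayed within the scatter. The aryl change recovers only part of the gap, so directly attached aryl groups remain on the weaker side of the linked compounds, and no measurement at hand accounts for either effect.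

The compounds shown leave open whether the step between the two directly attached aryl groups belongs to the trifluoromethyl group, to its 4-position, or to the loss of the 3-fluoro group. They also leave open how a plain phenyl or a 4-methoxyphenyl group would behave, either directly on this nitrogen or at the end of the carbamoylamino link.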